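The compounds below may be only part of what the source reports. "The series", "measured", "known", "first", "only" and "open" are said of these compounds alone.

Three compounds have been measured in a functional assay for agonist activity at G protein-coupled receptor 88 (Homo sapiens), read by HTRF and cAMP accumulation; on this read-out lower numbers stand for an effect already at smaller amounts and higher numbers for an effect only at larger amounts of compound:

Compound 1 `N[C@@H](CC1CCCCC1)CN(C(=O)[C@@H]1C[C@H]1c1ccccc1)c1ccc(-c2ccccc2)cc1`: 1.7 nM
Compound 2 `CC[C@H](C)[C@H](N)CN(C(=O)[C@@H]1C[C@H]1c1cccc(C)c1)c1ccc(-c2ccccc2)cc1`: 1200 nM
Compound 3 `CC(C)C[C@H](N)CN(C(=O)[C@@H]1C[C@H]1c1ccccc1)c1ccc(C2=CCCCCC2)cc1`: 2100 nM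

Compound 3 has the highest number of the three. Compound 2 sits close to it, within the usual scatter, so the two cannot be ranked; compound 1 lies far lower, well beyond the scatter. Compound 4 `CC(C)C[C@H](N)CN(C(=O)[C@@H]1C[C@H]1c1ccccc1)c1ccc(-c2cccc(C#N)c2)cc1` differs from compound 3 in a single place: 3-cyanophenyl in place of cyclohept-1-en-1-yl on an aromatic carbon. Going by the values given here, no measured pair isolates this change, and compound 1 differs from compound 4 in more than one place, so its low value is only a hint. Still, a clear downward step is expected, a 21-fold lower number from compound 3 to compound 4 (1.32 log units; beyond the scatter), beyond the scatter. Compound 4 is therefore estimated at 100 nM, with a likely range from 20 nM to 600 nM.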

Compound 4, half-maximal effective concentration: 4500 nM
For compound 4 the middle estimate is 45-fold (1.65 log units) below the measured one, and the stated range ends below it.
By their numbers in this assay, from the lowest: compound 1; then compounds 2 and 3 (each within the scatter of the next); then compound 4.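

In this assay, 3-cyanophenyl in place of cyclohept-1-en-1-yl on this aromatic carbon gives a 2.1-fold higher number from compound 3 to compound 4 (0.33 log units; beyond the scatter), a modest step. At this position, then, exchanging a non-aromatic seven-membered ring for an aromatic ring carrying a nitrile changes the number only slightly, and the change is not towards lower numbers. Nothing available explains this step.

As far as these compounds go, it remains open whether the nitrile or the aromatic ring itself accounts for the step. A 3-methoxyphenyl or 4-cyanophenyl group at this position could help separate the two.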